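The compounds below may be only part of what the source reports. "The series", "measured", "known", "first", "only" and "open" are said of these compounds alone.

In a functional assay on HCT-116 cells (Homo sapiens) for cytotoxicity, read by MTT assay, with a stated time of 24 h (on this read-out higher numbers stand for weaker inhibition and lower numbers for stronger inhibition), compound 1 `O=S(=O)(O)OCCCCCCCCCC[Se]c1ccccc1` gives > 100000 nM, which is a limit of the assay and not a number. Compound 2 `O=S(=O)(O)OCCCCCCCCCC[Te]c1ccccc1` reads 7470 nM, and compound 3 `O=S(=O)(O)OCCCCCCCCCCCC[Te]c1ccccc1` reads 19800 nM. Compound 2 therefore holds the lower of the two actual numbers, with compound 3 as its nearest neighbour. Tellurium in place of selenium accounts for the step of an at least 13-fold lower number from compound 1 to compound 2 (1.12 log units; beyond the scatter), a large one, but compound 4 `O=S(=O)(O)OCCCCCCCC[Te]c1ccccc1` keeps the tellurium atom of compound 2, so this step says little about the new change. That change is sulfooxy in place of 2-(sulfooxy)ethyl on a saturated chain carbon, eight bonds along the chain from a tellurium atom. The measured step closest to it is a 2.7-fold higher number from compound 2 to compound 3 (0.42 log units; beyond the scatter), a modest one, in which 2-(sulfooxy)ethyl replaced sulfooxy, the reverse kind of exchange. Read backwards, this points towards a lower number in this assay, although a single step establishes no trend and the direction could fail to hold at the shorter chain. The expected step is a 1.7-fold lower number from compound 2 to compound 4 (0.22 log units; within the scatter), deliberately smaller than the measured one. For compound 4 the estimated value is 4500 nM, with an expected range from 1500 nM to 15000 nM.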

Compound 4, half-maximal inhibitory concentration: 5990 nM
The estimate for compound 4 lay 1.3-fold (0.12 log units) below the measured number, within the range that was stated.
By their numbers in this assay, from the lowest: compounds 4 and 2 (each within the scatter of the next); then compound 3. At a limit, above all of these: compound 1.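

In this assay, removing the 2-(sulfooxy)ethyl group in favour of sulfooxy at this place on the chain gave a 1.2-fold lower number from compound 2 to compound 4 (0.10 log units; within the scatter), so this change does not separate the two compounds, and the tellurium compound keeps a measured number at the shorter chain. The exchange in the opposite kind, a 2.7-fold higher number from compound 2 to compound 3 (0.42 log units; beyond the scatter), had lain beyond the scatter, so among these three tellurium compounds only the longest chain stands apart from compound 2, and the direction suggested by that earlier step does not show up as a real difference here. The data shown offer no explanation for why one exchange registers and the other does not.

As far as these compounds go, what remains open is whether the flat stretch continues to a chain shorter than that of compound 4, or whether a still longer chain than that of compound 3 would carry the number further upward. From the compounds shown here alone, it is also open whether a carboxylic acid or an amine at the chain end, in place of sulfooxy, would keep a number in the same region in this assay.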